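This account rests on a few compounds, and the source may have more. Where it says the series, first, only, none or still open, it means among the compounds named here.

Notes on the series. Compound 1 `CC(C)OC(=O)c1ccc(NCc2cncn2Cc2ccc(-c3ccccc3)cc2)cc1-c1ccccc1` carries the shared core with an isopropoxycarbonyl on the aromatic ring. In a toxicity assay on NIH3T3 cells (Mus musculus) for cytotoxicity, read by resazurin assay (on this read-out lower numbers stand for an effect already at smaller amounts and higher numbers for an effect only at larger amounts of compound), compound 1 gives > 10000 nM, which is a limit of the assay and not a number. The value of compound 1 sits at the limit of > 10000 nM in this assay, at which 1 of the 2 values shown sits. Compound 2 `COc1ccc(NCc2cncn2Cc2ccc(-c3ccccc3)cc2N)cc1-c1ccccc1` is the second measured member. In this assay compound 2 gives > 1000 nM, again a limit rather than a number. The value of compound 2 sits at the limit of > 1000 nM in this assay, at which 1 of the 2 values shown sits. Where compound 1 stands on the numbers shown is therefore known only as a limit, and no step between measured compounds can be read.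

Compound 3 `CCC(=O)c1ccc(NCc2cncn2Cc2ccc(-c3ccccc3)cc2)cc1-c1ccccc1` is not yet measured in this assay. It differs from compound 1 by ethyl in place of isopropoxy on a carbonyl carbon. With both measured values being limits, nothing in the data points to a step in this assay beyond the scatter in either direction. Compound 3 is expected to give about 20000 nM in this assay, within a range from 5000 nM to 100000 nM, most likely reported once more as a limit. The step that the limit leaves unreadable from compound 1 to compound 3 is estimated as none beyond the scatter.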

Compound 3, half-maximal effective concentration: > 10000 nM
Compound 3: a limit, no number (the forecaster's own chance of this, stated with the estimate: 80%); the middle value lies beyond the limit too.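

No step can be read between compound 1 and compound 3: in this assay compound 3 gives > 10000 nM, which is a limit of the assay and not a number. The compounds shown leave open at which concentration any of them takes effect in this assay, and whether ethyl in place of isopropoxy on a carbonyl carbon changes the value at all.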